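This account rests on a few compounds, and the source may have more. Where it says the series, first, only, none or still open, it means among the compounds named here.

Of the compounds shown here, three have been measured so far in a physicochemical assay for solubility, read by nephelometry, measured as kinetic solubility, at pH 6.5; a higher number here means a more soluble compound, a lower number a less soluble compound. Compound 1 `NCc1csc(NC(=O)c2cnnn2Cc2ccccc2)n1` gives 50 ug/mL there and compound 3 `COc1ccc(C(=O)Nc2nc(CN)cs2)cc1` gives 25 ug/mL there, two values within the usual scatter of each other. Compound 2 `CC(C)(C)c1cc(C(=O)Nc2nc(CNS(C)(=O)=O)cs2)n(Cc2ccccc2)n1` gives 3.1 ug/mL in the same test, a number beyond the scatter from that of compound 1, which therefore belongs to the upper pair of this small set.

Compound 4 `NCc1csc(NC(=O)c2cnn[nH]2)n1` has not yet been measured. It carries hydrogen in place of benzyl on an aromatic nitrogen and otherwise matches compound 1. For the measured compounds named here, no two measured compounds differ in one place only, so no direct step guides the expectation. The indirect evidence is thin: compound 3 has no benzyl and gives 25 ug/mL in this assay, within the scatter of compound 1 at 50 ug/mL with its benzyl, while compound 2 also carries a benzyl and gives 3.1 ug/mL on a different scaffold. The estimated change, a 1.4-fold higher number from compound 1 to compound 4 (0.15 log units; within the scatter) in this assay, is a small upward step that is expected to stay within the scatter. For compound 4 the expected value is 70 ug/mL, with an estimated range from 25 ug/mL to 150 ug/mL in this test.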

Compound 4, solubility: > 100 ug/mL
Compound 4 gave a limit, no number; the forecaster's own chance of this, stated with the estimate: 20%; middle value at least 1.4-fold (0.15 log units) away from the limit.
By their numbers in this assay, from the lowest: compound 2; then compounds 3 and 1 (each within the scatter of the next). At a limit, above all of these: compound 4.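

In this assay compound 4 gives > 100 ug/mL, which is a limit and not a number. For the compounds shown here, this pair is the only one in the set that differs in one place, so it gives the first direct reading at this aromatic nitrogen: hydrogen in place of benzyl appears as an at least 2.0-fold higher number from compound 1 to compound 4 (0.30 log units; that floor lies within the scatter), and the size printed there is a floor, not a measured distance. The whole benzyl, with its six-membered aromatic ring of carbon only, can therefore leave this position without a lower number in this test, and among the compounds shown only compound 4 reaches the limit: the limit of > 100 ug/mL in this assay, at which 1 of the 4 values shown sits.

On these data alone, the true size of the step remains open, and so does whether it lies beyond the scatter, since only its floor can be read. The compounds shown also leave open whether a methyl or a longer chain such as ethyl on this same nitrogen would stay at that limit or fall back towards compound 1, and whether the same change would act alike on the core of compound 2.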